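Aryl substituent variation on a fused aza-aromatic core

The source may report more compounds than this note shows. Statements on the series, on what has been measured and on what is new or still open speak of the compounds shown alone.

Measured compounds and their values:
- compound 1, `Cc1nc2c3ccccc3ccc2c2nc3c(ccc4ccccc43)c(-c3cc([N+](=O)[O-])ccc3N)c12`: 93.1 ug/mL
- compound 2, `Cc1nc2c3ccccc3ccc2c2nc3c(ccc4ccccc43)c(C)c12`: 129 ug/mL
- compound 3, `COc1ccc(-c2c3ccc4ccccc4c3nc3c2c(C)nc2c4ccccc4ccc32)cc1`: 133 ug/mL

All three share one core and differ only in the group on a single aromatic carbon. In a functional assay, read by spectrophotometry, with a stated time of 30 min (a lower number here means a stronger inhibitor, a higher number a weaker inhibitor), compound 1 gives 93.1 ug/mL, compound 2 gives 129 ug/mL and compound 3 gives 133 ug/mL. Compound 3 stands within the usual scatter of both others: a 1.4-fold higher number from compound 1 to compound 3 (0.15 log units; within the scatter) and a 1.0-fold higher number from compound 2 to compound 3 (0.01 log units; within the scatter). Likewise a 1.4-fold higher number from compound 1 to compound 2 (0.14 log units; within the scatter). Across the series the number has so far been insensitive to what occupies this carbon, whether methyl, 4-methoxyphenyl or 2-amino-5-nitrophenyl.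

Compound 4, `Cc1nc2c3ccccc3ccc2c2nc3c(ccc4ccccc43)c(-c3cc(O)nc4ccccc34)c12`, has not been measured. It differs from compound 3 as follows: 2-hydroxyquinolin-4-yl in place of 4-methoxyphenyl on an aromatic carbon. Within the data shown here, the steps that bear on this are those at the same aromatic carbon, from compound 2 to compound 3 and from compound 1 to compound 3, both within the scatter. A 2-hydroxyquinolin-4-yl group has not been tried, so the expectation rests only on the inertness of this position seen so far; the estimated step of a 1.0-fold lower number from compound 3 to compound 4 (0.01 log units; within the scatter) is therefore no change beyond the scatter. Compound 4 is expected to give about 130 ug/mL in this assay, with a range from 65 ug/mL to 260 ug/mL.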

Compound 4, half-maximal inhibitory concentration: 92.1 ug/mL
Compound 4: the middle estimate sits 1.4-fold (0.15 log units) above what was measured; the measured number falls inside the stated range.
By their numbers in this assay, from the lowest: compounds 4, 1, 2 and 3 (each within the scatter of the next).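

In this assay a step of a 1.4-fold lower number from compound 3 to compound 4 (0.16 log units; within the scatter) shows that this aromatic carbon, opposite the ring nitrogen, can carry a larger group with a second aromatic ring, one holding a ring nitrogen, and a hydrogen-bond donor that 4-methoxyphenyl lacks, and the number stays within the scatter. The comparisons with the smallest group shown, a step of a 1.4-fold lower number from compound 2 to compound 4 (0.15 log units; within the scatter) and with the other substituted aryl group, a step of a 1.0-fold lower number from compound 1 to compound 4 (0.00 log units; within the scatter) and also within the scatter, leave methyl, 4-methoxyphenyl, 2-amino-5-nitrophenyl and 2-hydroxyquinolin-4-yl indistinguishable in this assay and extend the flat picture to a group containing a hetero atom in its ring. No measurement is at hand that would explain why this position shows so little response.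

Still open, from the compounds shown here alone, is whether the flat picture holds for a group of another kind on this carbon, such as a carboxylic acid, a basic amine on a longer chain or a simple halogen like chlorine. Also open, going by these compounds, is whether any change elsewhere on the shared core would move the number beyond the scatter, since all four compounds differ at this one carbon only.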